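The source may report more compounds than this note shows. Statements on the series, on what has been measured and on what is new or still open speak of the compounds shown alone.

Measured compounds: compound 1 `Cc1ccc(NC(=O)NCCCOc2cccc(CN3CCCCC3)c2)cc1` with 631 nM; compound 2 `CCCNC(=O)NCCCOc1cccc(CN2CCCCC2)c1` with 97.7 nM.

Among the compounds with values here, in an assay on isolated protein for inhibition of histamine H2 receptor (Cavia porcellus) (on this read-out higher numbers stand for weaker binding and lower numbers for tighter binding), compound 2 gives the lower of the two numbers, with compound 1 the only neighbour, a step of a 6.5-fold lower number from compound 1 to compound 2 (0.81 log units; beyond the scatter) away. Compound 3 `O=C(NCCCOc1cccc(CN2CCCCC2)c1)Nc1cccc(Cl)c1` differs from compound 2 by 3-chlorophenyl in place of propyl on an amide-type nitrogen. Within the data shown here, the one step that bears on this, a 6.5-fold lower number from compound 1 to compound 2 (0.81 log units; beyond the scatter), went the other way: replacing an aryl group by propyl gave a lower number, so returning to an aryl group is expected to give a higher number. Compound 3 is therefore expected to show a 4.1-fold higher number from compound 2 to compound 3 (0.61 log units; beyond the scatter) in this assay, an estimate of 400 nM with a range from 120 nM to 1300 nM.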

Compound 3, dissociation constant: 316 nM
Compound 3: the middle estimate sits 1.3-fold (0.10 log units) above what was measured; the range from low to high includes it.
By their numbers in this assay, from the lowest: compound 2; then compounds 3 and 1 (each within the scatter of the next).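

In this assay, the step of a 3.2-fold higher number from compound 2 to compound 3 (0.51 log units; beyond the scatter) shows that a second aryl group, 3-chlorophenyl in place of propyl on the amide-type nitrogen, also gives a higher number than propyl. The step of a 2.0-fold lower number from compound 1 to compound 3 (0.30 log units; within the scatter) does not separate 3-chlorophenyl from 4-methylphenyl at this place, so compound 2 stays lowest of the three. No evidence at hand accounts for this result. Still open, from the compounds shown here alone, is whether a longer chain such as butyl, or a saturated ring such as cyclohexyl, on this nitrogen would read like propyl or like the aryl groups.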